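Bromine for chlorine on the benzylic ring of compound 3

This account rests on a few compounds, and the source may have more. Where it says the series, first, only, none or still open, it means among the compounds named here.

Of the compounds shown here, three built on a shared core have been measured in an assay on isolated protein for inhibition of Amine oxidase [flavin-containing] B (Homo sapiens), read by Amplex Red, with a stated time of 15 min; on this read-out higher numbers stand for weaker inhibition and lower numbers for stronger inhibition. Compound 1 `CC(=O)c1ccc(OCc2ccc(F)cc2F)cc1` gives 27.3 nM. Compound 2 `CC(=O)c1cccc(OCc2cccc(F)c2)c1` gives 193 nM. Compound 3 `CC(=O)c1cccc(OCc2cccc(Cl)c2)c1` gives 34.2 nM. Among these, compound 3 lies close to compound 1, the two being within the usual scatter, and well apart from compound 2, which carries fluoro where compound 3 carries chloro. For the measured compounds named here, that single exchange is the one measured step that bears on the question here: a 5.6-fold lower number from compound 2 to compound 3 (0.75 log units; beyond the scatter).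

Compound 4 `CC(=O)c1cccc(OCc2cccc(Br)c2)c1` is not yet measured. It differs from compound 3 in one place: bromo in place of chloro on an aromatic carbon. Going by the values given here, the step from compound 2 to compound 3 shows that a larger halogen at this position went with a clearly lower number, but no measured pair shows what bromo does in the same place, so the size of the next step can only be judged from that one step. The expectation is that compound 4 moves little, or somewhat downward, from compound 3, the estimated step being a 1.4-fold lower number from compound 3 to compound 4 (0.15 log units; within the scatter). For compound 4 the estimate in this assay is 24 nM, with a range from 9 nM to 65 nM.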

Compound 4, half-maximal inhibitory concentration: 96.3 nM
Compound 4: middle estimate off by 4.0-fold (0.60 log units), on the low side; the whole stated range lies below it.
By their numbers in this assay, from the lowest: compounds 1 and 3 (each within the scatter of the next); then compounds 4 and 2 (each within the scatter of the next).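

In this assay this position does not follow a one-way trend across the halogens, since the fall seen in a 5.6-fold lower number from compound 2 to compound 3 (0.75 log units; beyond the scatter) does not carry on to bromo, which instead gives a 2.8-fold higher number from compound 3 to compound 4 (0.45 log units; beyond the scatter) at the same place. Bromo and fluoro cannot be told apart here, with a 2.0-fold lower number from compound 2 to compound 4 (0.30 log units; within the scatter) in this comparison, so among these three compounds chloro alone stands apart, and both of its steps lie beyond the scatter. Nothing among the data explains why chloro differs from the other two halogens at this position.

The compounds shown leave open how a group other than a halogen, such as methyl, methoxy, nitrile or an amine, would compare with chloro at this same place, and how the ring without any such group would compare. They also leave open whether chloro would keep its place ahead of fluoro and bromo elsewhere on this ring or on a core with the acetyl group placed as in compound 1.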